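The source may hold more compounds than are shown below. What is called first, only, known or untested is meant among the compounds shown, and "the series" means these compounds.

Compound 1 has the structure `Fc1cccc(Cc2nnc(Cn3nnc4ccccc43)o2)c1`. Compound 2 has the structure `COc1ccccc1Cc1nnc(Cn2nnc3ccccc32)o1`. Compound 3 has the structure `Brc1cccc(-c2nnc(Cn3nnc4ccccc43)o2)c1`. These three compounds share one core and were tested in an ADME assay on cells (Macrophage, Homo sapiens) for inhibition; on this read-out higher numbers stand for lower toxicity in this test and lower numbers for higher toxicity in this test. For compound 1 the result is a limit of the assay, > 100000 nM. For compound 2 the result is likewise a limit, > 100000 nM. For compound 3 the result is again a limit, > 100000 nM. The single one-point step shown, a step that the two limits leave unreadable from compound 1 to compound 2, is unreadable; both of its ends are limits. Compound 3 thus stands at the limit of > 100000 nM in this assay, at which 3 of the 3 values shown sit. Compound 4 `COc1cccc(-c2nnc(Cn3nnc4ccccc43)o2)c1` differs from compound 3 by methoxy in place of bromo on an aromatic carbon. Within the data shown here, no measured step bears directly on this change. The step expected is a number no higher from compound 3 to compound 4 (the limit leaves the size open), none beyond the scatter. Compound 4 is therefore expected to give 100000 nM in this assay, estimated between 50000 nM and 200000 nM.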

Compound 4, half-maximal cytotoxic concentration: > 100000 nM
Compound 4: no number, only a limit (the forecaster's own chance of this, stated with the estimate: 85%); the middle value lies on the limit itself.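

No step can be read between compound 3 and compound 4: each result is a limit of the assay, not a number. The compounds shown leave open where any of their true values lies in this assay.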